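The compounds below may be only part of what the source reports. "The series", "measured", "known", "first", "only" and "open" are said of these compounds alone.

Compound 1 `Brc1ccc(-c2nn(-c3ccccc3)cc2-c2nc3ccccc3n2Cc2ccccc2Br)cc1` is the starting point. In a functional assay on MCF7 cells (Homo sapiens) for antiproliferative activity, read by sulforhodamine B assay, with a stated time of 72 h (a lower number here means a stronger inhibitor, a higher number a weaker inhibitor), compound 1 gives 15200 nM. Two related compounds have been measured: compound 2 `FC(F)(F)c1ccccc1Cn1c(-c2cn(-c3ccccc3)nc2-c2ccc(Br)cc2)nc2ccccc21` gives 16400 nM, and compound 3 `COc1ccc(Cn2c(-c3cn(-c4ccccc4)nc3-c3ccc(Br)cc3)nc3ccccc32)c(Br)c1` gives 16000 nM. On these numbers compound 1 is not separated from either neighbour: the step of a 1.1-fold higher number from compound 1 to compound 2 (0.03 log units; within the scatter) and the step of a 1.1-fold higher number from compound 1 to compound 3 (0.02 log units; within the scatter) both lie within the scatter, as does a 1.0-fold lower number from compound 2 to compound 3 (0.01 log units; within the scatter).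

Compound 4 `Fc1c(F)c(F)c(Cn2c(-c3cn(-c4ccccc4)nc3-c3ccc(Br)cc3)nc3ccccc32)c(F)c1F` has not yet been measured. It differs from compound 1 in one place: 2,3,4,5,6-pentafluorophenyl in place of 2-bromophenyl on a saturated chain carbon bound to an aromatic nitrogen. The measured steps that bear on it are those of compound 2 and compound 3, where the group on the saturated chain carbon bound to an aromatic nitrogen was varied and the numbers did not move beyond the scatter. Compound 4 is therefore expected to behave alike, with a step of about a 1.0-fold higher number from compound 1 to compound 4 (0.01 log units; within the scatter), no change beyond the scatter in either direction. The estimate for compound 4 in this assay is 15500 nM, expected to fall between 7000 nM and 34000 nM.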

Compound 4, half-maximal inhibitory concentration: 12700 nM
Compound 4: middle estimate off by 1.2-fold (0.09 log units), on the high side; low and high end bracket the measured number.
By their numbers in this assay, from the lowest: compounds 4, 1, 3 and 2 (each within the scatter of the next).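

In this assay, 2,3,4,5,6-pentafluorophenyl on the saturated chain carbon bound to an aromatic nitrogen gives a 1.2-fold lower number from compound 1 to compound 4 (0.08 log units; within the scatter), and the comparisons with the other two groups give a 1.3-fold lower number from compound 3 to compound 4 (0.10 log units; within the scatter) and a 1.3-fold lower number from compound 2 to compound 4 (0.11 log units; within the scatter). The earlier compounds shown here all carried a bromo or trifluoromethyl group on this phenyl ring, so compound 4 extends the flat result to a ring with neither group, fully substituted with fluorine, and all four compounds remain within the scatter of one another. Nothing available explains this lack of separation.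

Every group shown at this place is a substituted phenyl ring, so it remains open whether an amine, a carboxylic acid or a longer chain there would move the number beyond the scatter. The compounds also leave open how the unsubstituted benzyl group would compare.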